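The source may hold more compounds than are shown below. What is called first, only, known or untested is meant among the compounds shown, and "the series" means these compounds.

Measured compounds in a functional assay on MGC-803 cells (Homo sapiens) for inhibition, read by MTT assay, with a stated time of 72 h; a higher number here means a weaker inhibitor, a lower number a stronger inhibitor:

compound 1 `Cc1cc(N2CC[C@@H](C)[C@@H](N(C)c3ncnc4[nH]ccc34)C2)n2ncnc2n1` gives 4350 nM
compound 2 `Cc1cc(N2CC[C@@H](C)[C@@H](N(C)c3ncnc4[nH]ccc34)C2)n2nc(SCc3ccc(C(F)(F)F)cc3)nc2n1` gives 2680 nM
compound 3 `Cc1cc(N2CC[C@@H](C)[C@@H](N(C)c3ncnc4[nH]ccc34)C2)n2nc(SCc3cc(Cl)ccc3Cl)nc2n1` gives 9850 nM

Compound 1 holds the second highest of the three numbers in this assay. Compound 2 is nearest to it, and the step is a 1.6-fold lower number from compound 1 to compound 2 (0.21 log units; within the scatter). Compound 3 lies furthest from it, with a 2.3-fold higher number from compound 1 to compound 3 (0.35 log units; beyond the scatter). The two measured substituents on the shared core thus pull in opposite directions, and between them the step is a 3.7-fold higher number from compound 2 to compound 3 (0.57 log units; beyond the scatter).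

Compound 4 `Cc1cc(N2CC[C@@H](C)[C@@H](N(C)c3ncnc4[nH]ccc34)C2)n2nc(SCc3ccccc3)nc2n1` is not yet measured. Its change from compound 1 is benzylsulfanyl in place of hydrogen on an aromatic carbon. Both measured steps from compound 1 bear on this one, as each replaces the same hydrogen with a benzylsulfanyl group carrying a substituent on the phenyl ring. The step to compound 2 stays within the scatter, the step to compound 3 goes modestly beyond it; the unsubstituted benzyl of compound 4 gives no ground to expect either direction in particular. Compound 4 is therefore expected to sit close to compound 1, with a 1.0-fold higher number from compound 1 to compound 4 (0.01 log units; within the scatter) as the expected step. The estimate for compound 4 in this assay is 4500 nM, with a range from 1800 nM to 11000 nM.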

Compound 4, half-maximal inhibitory concentration: 5870 nM
Beside the measured number, compound 4's estimate is 1.3-fold (0.12 log units) below it; measured number inside the range.
By their numbers in this assay, from the lowest: compounds 2, 1, 4 and 3 (each within the scatter of the next, the first and the last beyond it).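

In this assay the unsubstituted benzylsulfanyl, placed on the aromatic carbon between two ring nitrogen atoms, adds a whole phenyl ring to the core of compound 1 with no shift beyond the scatter, at a 1.3-fold higher number from compound 1 to compound 4 (0.13 log units; within the scatter). It also gives the substituted benzyl groups a direct reference: removing trifluoromethyl gives a 2.2-fold higher number from compound 2 to compound 4 (0.34 log units; beyond the scatter), beyond the scatter, whereas phenyl in place of 2,5-dichlorophenyl gives a 1.7-fold lower number from compound 3 to compound 4 (0.22 log units; within the scatter), within it. No measurement at hand explains these steps.

Compounds 2 and 3 differ in both the identity and the placement of their phenyl substituents, so the contribution of each remains unresolved. Also open, as far as these compounds go, is how an amine or a carboxylic acid on the phenyl ring, or a longer alkyl chain in place of benzyl, would read in this assay.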